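The source may hold more compounds than are shown below. What is called first, only, known or untested is meant among the compounds shown, and "the series" means these compounds.

Working notes on the series. For the measured compounds named here, compound 1 `C[C@H]1CN(c2ncc(C(=O)Nc3nc(-c4cccc(C(F)(F)F)c4F)cs3)cc2Cl)CC1C(=O)O` is one of two compounds measured in a physicochemical assay for solubility; a higher number here means a more soluble compound, a lower number a less soluble compound. In this assay compound 1 gives < 10 ug/mL, which is a limit of the assay and not a number. Compound 2 `O=C(Nc1nc(-c2cccc(C(F)(F)F)c2F)cs1)c1ccc(N2CCC(C(=O)O)CC2)nc1` in this assay gives < 10 ug/mL, likewise a limit. Compound 1 therefore stands at the limit of < 10 ug/mL in this assay, at which 2 of the 2 values shown sit. Compound 3 `O=C(Nc1nc(-c2cccc(C(F)(F)F)c2F)cs1)c1cnc(N2CCC(c3nn[nH]n3)CC2)c(Cl)c1` differs from compound 1 by 4-(2H-tetrazol-5-yl)piperidin-1-yl in place of 3-carboxy-4-methylpyrrolidin-1-yl on an aromatic carbon. Going by the values given here, no measured step covers this change, and no move beyond the scatter is expected, so the expected step is a step that the limit leaves unreadable from compound 1 to compound 3. Compound 3 is expected to give 8 ug/mL, between 2 ug/mL and 30 ug/mL.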

Compound 3, solubility: < 10 ug/mL
Compound 3: no number, only a limit (the forecaster's own chance of this, stated with the estimate: 55%); the middle value is on the limit's open side.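

No new step can be read between compound 1 and compound 3, because in this assay both values are limits of the assay and not numbers: the limit of < 10 ug/mL in this assay, at which 3 of the 3 values shown sit. The compounds shown leave open whether exchanging 3-carboxy-4-methylpyrrolidin-1-yl for 4-(2H-tetrazol-5-yl)piperidin-1-yl moves the read-out at all.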